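The source may report more compounds than this note shows. Statements on the series, on what has been measured and on what is new or still open speak of the compounds shown alone.

Measured in a functional assay on MV4-11 cells (Homo sapiens) for antiproliferative activity, read by CCK-8 assay, with a stated time of 72 h; on this read-out lower numbers stand for stronger inhibition and higher numbers for weaker inhibition:
- compound 1 `CC(C)Oc1ccccc1-c1cn(C)c(=O)c2[nH]c(C(=O)NCc3ccc(C(=O)Nc4ccccc4N)cc3)cc12`: 130 nM
- compound 2 `COc1cccc(-c2cn(C)c(=O)c3[nH]c(C(=O)NCc4ccc(C(=O)Nc5ccccc5N)cc4)cc23)c1`: 250 nM
- compound 3 `COc1ccc(C(C)(C)O)cc1-c1cn(C)c(=O)c2[nH]c(C(=O)NCc3ccc(C(=O)Nc4ccccc4N)cc3)cc12`: 420 nM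

Among these three, the nearest gap for compound 3 is a 1.7-fold higher number from compound 2 to compound 3 (0.23 log units; within the scatter), and the widest is a 3.2-fold higher number from compound 1 to compound 3 (0.51 log units; beyond the scatter).

Compound 4 `Cn1cc(-c2ccc(F)cc2)c2cc(C(=O)NCc3ccc(C(=O)Nc4ccccc4N)cc3)[nH]c2c1=O` has 4-fluorophenyl in place of 5-(1-hydroxy-1-methylethyl)-2-methoxyphenyl on the same aromatic carbon: 4-fluorophenyl in place of 5-(1-hydroxy-1-methylethyl)-2-methoxyphenyl on an aromatic carbon.

Three measured exchanges at this carbon bear on it. Besides the two above, there is a 1.9-fold higher number from compound 1 to compound 2 (0.28 log units; within the scatter). Going by the values given here, none of the measured compounds carries 4-fluorophenyl, so the direction is uncertain. In this assay, a small step is expected, probably none beyond the scatter.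

The expected step is a 1.6-fold lower number from compound 3 to compound 4 (0.21 log units; within the scatter).

Compound 4 is estimated at 260 nM, with an expected range of 100 nM to 650 nM.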

Compound 4, half-maximal inhibitory concentration: 220 nM
Compound 4: middle estimate off by 1.2-fold (0.07 log units), on the high side; the range from low to high includes it.
By their numbers in this assay, from the lowest: compounds 1, 4, 2 and 3 (each within the scatter of the next, the first and the last beyond it).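

In this assay, 4-fluorophenyl, with no hydrogen-bond donors or acceptors, stays within the scatter of every earlier aryl group: a 1.9-fold lower number from compound 3 to compound 4 (0.28 log units; within the scatter), a 1.1-fold lower number from compound 2 to compound 4 (0.06 log units; within the scatter) and a 1.7-fold higher number from compound 1 to compound 4 (0.23 log units; within the scatter). This position therefore accepts a smaller group without an alkoxy substituent, and compound 4 falls within the scatter of both compound 1 and compound 3, although those two lie beyond the scatter of each other. No measurement shown gives a reason for this.

As far as these compounds go, whether an amine or a carboxylic acid on this phenyl ring would shift the number beyond the scatter remains open. So does the outcome of replacing the phenyl ring with a longer alkyl chain.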